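The source may report more compounds than this note shows. Statements on the series, on what has been measured and on what is new or still open speak of the compounds shown alone.

In a functional assay on MCF7 cells (Homo sapiens) for inhibition, read by CCK-8 assay, with a stated time of 48 h (a lower number here means a stronger inhibitor of growth, a higher number a weaker inhibitor of growth), compound 1 `Cc1ccccc1Nc1nc(Nc2ccc(N3CCN(C)CC3)cn2)ncc1Cl` gives 5210 nM and compound 2 `COc1ccc(CNc2nc(Nc3ccc(N4CCN(C)CC4)cn3)ncc2Cl)cc1` gives 17300 nM while compound 3 `Cc1cccc(Nc2nc(Nc3ccc(N4CCN(C)CC4)cn3)ncc2Cl)c1` gives 7160 nM as the second highest of the three numbers. Compound 3 sits within the scatter of compound 1 and beyond it from compound 2.

Compound 4 `CCc1ccc(Nc2nc(Nc3ccc(N4CCN(C)CC4)cn3)ncc2Cl)cc1` carries 4-ethylphenyl in place of 3-methylphenyl on a nitrogen on an aromatic ring and keeps the shared core. Among the compounds with values here, no measured compound carries 4-ethylphenyl, so the evidence is indirect.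

Within the data shown here, the nearest precedent is the exchange between the two methylphenyl groups, a 1.4-fold higher number from compound 1 to compound 3 (0.14 log units; within the scatter) and this stays small. The modest steps of a 3.3-fold higher number from compound 1 to compound 2 (0.52 log units; beyond the scatter) and a 2.4-fold lower number from compound 2 to compound 3 (0.38 log units; beyond the scatter) both involve 4-methoxybenzyl, which is less like the incoming group.

No change beyond the scatter is therefore expected in this assay and the direction is left open. The expected step is a 1.2-fold lower number from compound 3 to compound 4 (0.08 log units; within the scatter) and no more than that is read into it. Compound 4 is estimated at 6000 nM with an expected range of 2500 nM to 14000 nM for now.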

Compound 4, concentration for 50% growth inhibition: 8230 nM
Beside the measured number, compound 4's estimate is 1.4-fold (0.14 log units) below it; the range from low to high includes it.
By their numbers in this assay, from the lowest: compounds 1, 3 and 4 (each within the scatter of the next); then compound 2.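

In this assay, 4-ethylphenyl on a nitrogen on an aromatic ring joins the two methylphenyl groups as a change with little effect: a 1.1-fold higher number from compound 3 to compound 4 (0.06 log units; within the scatter) and a 1.6-fold higher number from compound 1 to compound 4 (0.20 log units; within the scatter) both stay within the scatter, so compounds 1, 3 and 4 cannot be told apart here. Compound 2 is now set apart from all three, with a 2.1-fold lower number from compound 2 to compound 4 (0.32 log units; beyond the scatter) as a further modest step, and 4-methoxybenzyl is the only group shown at this position that gives a step beyond the scatter. Nothing on hand explains this difference or the likeness of the other three groups.

As far as these compounds go, whether the gap of compound 2 follows the methoxy group or the benzyl link remains open, and 4-methoxyphenyl or plain benzyl would separate the two. Also open, from the compounds shown here alone, is whether an amine or a carboxylic acid on the phenyl ring, or a chain longer than ethyl, would move the number beyond the scatter.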